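Compound 4: a thiophen-2-yl hydrazone in the series

This account rests on a few compounds, and the source may have more. Where it says the series, first, only, none or still open, it means among the compounds named here.

Values in a functional assay on HCT-116 cells (Homo sapiens) for antiproliferative activity, read by MTT assay; on this read-out lower numbers stand for stronger inhibition and higher numbers for weaker inhibition:

- Compound 1 `Cn1c(=O)c(=O)n(C2CCCC2)c2nc(N/N=C/c3ccccc3)ncc21` gives > 100000 nM (a limit of the assay, not a number)
- Compound 2 `COc1cccc(/C=N/Nc2ncc3c(n2)n(C2CCCC2)c(=O)c(=O)n3C)c1` gives 45800 nM
- Compound 3 `Cn1c(=O)c(=O)n(C2CCCC2)c2nc(N/N=C/c3cccc(Cl)c3Cl)ncc21` gives 26400 nM

Among the compounds with values here, compound 3 and compound 2 are the only two with numbers, and they stand level: a 1.7-fold lower number from compound 2 to compound 3 (0.24 log units; within the scatter). Compound 4 `Cn1c(=O)c(=O)n(C2CCCC2)c2nc(N/N=C/c3cccs3)ncc21` carries thiophen-2-yl in place of 2,3-dichlorophenyl on a carbon with a double bond to nitrogen.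

The step closest to this change is its near reverse, an at least 3.7-fold lower number from compound 1 to compound 3 (0.57 log units; beyond the scatter), which replaces phenyl with 2,3-dichlorophenyl. The methoxy step, an at least 2.1-fold lower number from compound 1 to compound 2 (0.33 log units; beyond the scatter), points the same way. In both, a substituted ring gives a lower number than the plain phenyl of compound 1. The thiophen-2-yl ring also enters without a substituent, so a modest move toward weaker inhibition in this assay is expected. The expected size is a 2.3-fold higher number from compound 3 to compound 4 (0.36 log units; beyond the scatter). Compound 4 is estimated at 60000 nM, with an expected range of 25000 nM to 120000 nM.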

Compound 4, half-maximal inhibitory concentration: 52600 nM
For compound 4 the middle estimate is 1.1-fold (0.06 log units) above the measured one; the measured number falls inside the stated range.
By their numbers in this assay, from the lowest: compounds 3, 2 and 4 (each within the scatter of the next). At a limit, above all of these: compound 1.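

In this assay, thiophen-2-yl on this carbon stands level with both substituted phenyl rings: a 2.0-fold higher number from compound 3 to compound 4 (0.30 log units; within the scatter), and a 1.1-fold higher number from compound 2 to compound 4 (0.06 log units; within the scatter). A five-membered aromatic ring with one hetero atom and no substituent therefore gives a value in the same range as compound 2 and compound 3, so a substituent on the ring is not needed for a measurable value among the compounds shown. Against the plain phenyl ring the step is only a floor, an at least 1.9-fold lower number from compound 1 to compound 4 (0.27 log units; that floor lies within the scatter), so it does not settle whether thiophen-2-yl differs from phenyl here.

The groups shown at this carbon are all uncharged aromatic rings, so the effect of a pyridine ring, or of a phenyl ring bearing an amine or a carboxylic acid, remains open. Also open, as far as these compounds go, is whether any group here can give a step from compound 4 that lies beyond the scatter.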